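Morpholine for Diisopropylamine on a Chromone Dithiocarbamate Scaffold

The source may report more compounds than this note shows. Statements on the series, on what has been measured and on what is new or still open speak of the compounds shown alone.

Measured compounds:
- compound 1, `COc1ccc2occ(CSC(=S)N(C(C)C)C(C)C)c(=O)c2c1`: 4800 nM
- compound 2, `COc1ccc2oc(CSC(=S)N3CCOCC3)cc(=O)c2c1`: 3100 nM
- compound 3, `COc1ccc2oc(CSC(=S)N(C(C)C)C(C)C)cc(=O)c2c1`: 7200 nM

Three dithiocarbamates were tested in a functional assay on SW480 cells (Homo sapiens) for antiproliferative activity, read by MTT assay, with a stated time of 72 h; on this read-out lower numbers stand for stronger inhibition and higher numbers for weaker inhibition. Compound 3 gives 7200 nM, and in this assay compound 2 gives 3100 nM. The difference between them is morpholin-4-yl in place of diisopropylamino on a thiocarbonyl carbon, and the step it made is a 2.3-fold lower number from compound 3 to compound 2 (0.37 log units; beyond the scatter). Compound 1 gives 4800 nM in this assay. Compound 1 and compound 3 are built from the same atoms joined differently, and the difference between the two cores is not broken down here; their values lie within the scatter of each other.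

Compound 4, `COc1ccc2occ(CSC(=S)N3CCOCC3)c(=O)c2c1`, is not yet measured. It stands to compound 1 as compound 2 stands to compound 3: the change is morpholin-4-yl in place of diisopropylamino on a thiocarbonyl carbon, the same kind of change made once already among these compounds, at the same place. Since the earlier step was modest and the two cores gave values close to each other, the same step size is expected here, resting on compound 3 and the step of a 2.3-fold lower number from compound 3 to compound 2 (0.37 log units; beyond the scatter). The estimated step is a 2.2-fold lower number from compound 1 to compound 4 (0.34 log units; beyond the scatter). For compound 4 the expected value in this assay is 2200 nM, estimated between 1000 nM and 5000 nM.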

Compound 4, half-maximal inhibitory concentration: 7100 nM
For compound 4 the middle estimate is 3.2-fold (0.51 log units) below the measured one; measured number outside the range, above it.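

In this assay, placing morpholin-4-yl in place of diisopropylamino on the thiocarbonyl carbon of the core of compound 1 gives a 1.5-fold higher number from compound 1 to compound 4 (0.17 log units; within the scatter), so on this core the change leaves the number within the scatter. The step seen on the other core therefore does not carry over, and the two steps differ by more than repeated measurements would explain: the same change on two cores in this assay, a 2.3-fold lower number (0.37 log units; beyond the scatter) from compound 3 to compound 2 and a 1.5-fold higher number (0.17 log units; within the scatter) from compound 1 to compound 4, 3.4-fold (0.54 log units) apart, beyond the scatter of two such steps. This shows that in this series the size of the step depends on the core that carries it, but with a single pair on each core it does not show why the cores differ or how the change would behave on any further core.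

The compounds shown leave open whether other amines on the thiocarbonyl carbon, such as piperidine or dimethylamine, would also separate the two cores. They also leave open whether a step seen on one core can predict the step on the other for any group other than morpholin-4-yl.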